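A few compounds are considered here, and "the series" means these few. Any claim that something is new, unique, unknown or untested is made for them only; others in the source may bear on it.

Measured so far in an ADME assay on L6 cells (Rattus norvegicus) for cytotoxicity, read by fluorescence and resazurin assay, with a stated time of 70 h; on this read-out higher numbers stand for weaker inhibition and lower numbers for stronger inhibition:
Compound 1 `N=C(N)Nc1ccc2[nH]c(-c3ccc(Cl)cc3)nc2c1` gives 71.1 ug/mL.
Compound 2 `N=C(N)Nc1ccc2[nH]c(-c3ccc(-c4ccccc4)cc3)nc2c1` gives 46.2 ug/mL.

Among these two numbers compound 1 stands highest; the only other number is reached by the step of a 1.5-fold lower number from compound 1 to compound 2 (0.19 log units; within the scatter), a change that does not rise above the scatter, so the two compounds cannot be ranked against each other.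

Compound 3 `N=C(N)Nc1ccc2[nH]c(-c3ccc(C(=O)O)cc3)nc2c1` has not yet been measured in this assay. Its structure differs from compound 1 in one place: carboxy in place of chloro on an aromatic carbon. Within the data shown here, the only measured step, a 1.5-fold lower number from compound 1 to compound 2 (0.19 log units; within the scatter), also replaces the chloro at that same carbon, there by phenyl, and stays within the scatter. Among the measured compounds shown here, no measured step exchanges chloro for carboxy, so there is no direct guide for this particular change. For the measured compounds named here, with the single available step remaining inside the scatter, the expectation for compound 3 is a number close to that of compound 1, with no step beyond the scatter in either direction, written as a 1.1-fold higher number from compound 1 to compound 3 (0.05 log units; within the scatter). Compound 3 is therefore estimated at 80 ug/mL, within a range from 35 ug/mL to 160 ug/mL.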

Compound 3, half-maximal inhibitory concentration: > 100 ug/mL
Compound 3: a limit, no number; the forecaster's own chance of this, stated with the estimate: 20%; at least 1.2-fold (0.09 log units) between middle value and limit.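

In this assay compound 3 gives no number, only a limit of the assay: the limit of > 100 ug/mL in this assay, at which 1 of the 3 values shown sits.

Among these compounds, the step from the phenyl group to the carboxy group gives the first change at this carbon that rises beyond the scatter, an at least 2.1-fold higher number from compound 2 to compound 3 (0.33 log units; beyond the scatter), so the group para to the large core can shift the read-out towards weaker inhibition of the L6 cells, which the step between compound 1 and compound 2 alone could not show. The exchange of chloro for carboxy tells less, an at least 1.4-fold higher number from compound 1 to compound 3 (0.14 log units; that floor lies within the scatter), and since this floor stays within the scatter, compound 3 cannot yet be ranked against compound 1, although the true gap may prove larger.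

Among the compounds shown here, how far compound 3 really lies from the other two remains unknown, and with only three groups at this carbon, nothing shows which feature of the carboxy group matters. An amine or a primary amide at the same carbon, set against chloro and phenyl, could show whether the shift belongs to the carboxylic acid alone or extends to other groups.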